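The compounds below may be only part of what the source reports. "The series", "measured", "known", "first", "only" and "open" are said of these compounds alone.

Measured compounds in an assay on cells for positive allosteric modulation of Cystic fibrosis transmembrane conductance regulator variant F508del (Homo sapiens), with stated times of 10 min and 7 s, in the presence of a further agent that is not named here; on this read-out higher numbers stand for an effect only at larger amounts of compound and lower numbers for an effect already at smaller amounts:
Compound 1 `CC1(C)Cc2c(sc(NC(=O)c3cn[nH]c3)c2C(N)=O)C(C)(C)O1` gives 125 nM.
Compound 2 `CC1(C)Cc2c(sc(NC(=O)C(C)(C)CO)c2C(N)=O)C(C)(C)O1` gives 75 nM.
Compound 3 `CC1(C)Cc2c(sc(NC(=O)c3[nH]ncc3Cl)c2C(N)=O)C(C)(C)O1` gives 2 nM.

Compound 3 stands lowest of the three in this assay: its nearest neighbour is compound 2, with a 38-fold lower number from compound 2 to compound 3 (1.57 log units; beyond the scatter), and the furthest is compound 1, with a 63-fold lower number from compound 1 to compound 3 (1.80 log units; beyond the scatter). Both steps lie beyond the scatter, whereas the step of a 1.7-fold lower number from compound 1 to compound 2 (0.22 log units; within the scatter) does not.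

Compound 4 `Cc1cn[nH]c1C(=O)Nc1sc2c(c1C(N)=O)CC(C)(C)OC2(C)C` arises from compound 3 by a single change: methyl in place of chloro on an aromatic carbon. Going by the values given here, no measured pair separates the chloro from the ring that carries it; the large steps into compound 3 bring in the chloro together with a change of the whole five-membered ring, so they speak for the ring rather than for the chloro alone. The change to compound 4 keeps that ring and swaps one small group for another of the same size class.

On that basis compound 4 is expected to stay close to compound 3, with a modest step of a 3.0-fold higher number from compound 3 to compound 4 (0.48 log units; beyond the scatter) in this assay. The estimate for compound 4 is 6 nM, with a range from 1.5 nM to 25 nM.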

Compound 4, half-maximal effective concentration: 2 nM
The estimate for compound 4 lay 3.0-fold (0.48 log units) above the measured number, and the stated range covers the measured number.
By their numbers in this assay, from the lowest: compounds 3 and 4 (each within the scatter of the next); then compounds 2 and 1 (each within the scatter of the next).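

In this assay, the aromatic carbon two ring bonds from the ring nitrogen takes methyl in place of chloro with no change at the digits printed from compound 3 to compound 4 (within the scatter), so among the compounds shown the low number no longer depends on chloro, a point the earlier compounds could not settle. The large steps seen into compound 3 recur with the methyl group, as a 38-fold lower number from compound 2 to compound 4 (1.57 log units; beyond the scatter) and a 63-fold lower number from compound 1 to compound 4 (1.80 log units; beyond the scatter), although the second of these exchanges the whole group on the carbonyl carbon and does not isolate the methyl. No measured information explains why chloro and methyl give matching numbers at this place.

The compounds shown leave open whether a bare hydrogen at this aromatic carbon would give a number like that of compound 1 or like those of compound 3 and compound 4, which would show whether any group is needed there at all. They also leave open whether a longer chain such as propyl, an amine or a carboxylic acid at the same place would keep the number as low.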